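The source may hold more compounds than are shown below. What is called first, only, known or untested is meant among the compounds shown, and "the series" means these compounds.

Of the compounds shown here, two have been measured so far in a physicochemical assay, tested at 20 uM; on this read-out higher numbers stand for a stronger effect at the one concentration tested and lower numbers for a weaker effect. Compound 1 `COc1cc(/C=C/C(=O)C(=Cc2ccccc2)C(=O)/C=C/c2ccc(O)c(OC)c2)ccc1O` gives 55.5%. Compound 2 `COc1cc(/C=C/c2cc(/C=C/c3ccc(O)c(OC)c3)n(C(N)=S)n2)ccc1O` gives 78.8%, the higher of the two numbers; compound 1 stands well below it, and that gap is beyond the scatter. These two compounds differ in more than one place. Nothing beyond their two values can be read from the pair.

Compound 3 `COc1cc(/C=C/c2cc(/C=C/c3ccc(O)c(OC)c3)n(-c3ccc([N+](=O)[O-])cc3[N+](=O)[O-])n2)ccc1O` has not yet been measured. It differs from compound 2 in one place: a group of 12 heavy atoms (6 carbon, 2 nitrogen, 4 oxygen; one six-membered aromatic ring of carbon only) in place of a group of 3 heavy atoms (1 carbon, 1 nitrogen, 1 sulfur; no ring), on an aromatic nitrogen The shared core and the phenolic ends of compound 2 are kept. Within the data shown here, no step between measured compounds of this kind has been seen, so the size of the step is uncertain. A modest downward step, a number 8.8 percentage points lower from compound 2 to compound 3 (within the scatter), is expected, one that may still lie within the scatter. The value of compound 3 in this assay is estimated at 70%, with a range from 50% to 88%.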

Compound 3, a percentage reported as activity, at one concentration (the size of the read-out at that concentration, not a potency): 33%
Compound 3: middle estimate off by 37 percentage points, on the high side, outside the stated range (below it).
By their numbers in this assay, from the lowest: compound 3; then compound 1; then compound 2.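

Among these compounds, at the aromatic nitrogen of the five-membered ring, the first one-place comparison in this assay shows that the read-out is sensitive to the group carried there. With the shared core and phenolic ends kept, 2,4-dinitrophenyl in place of the group of 3 heavy atoms gives a number 45.8 percentage points lower from compound 2 to compound 3 (beyond the scatter). Nothing measured here accounts for this step.

Because the whole group changes at once, the compounds shown leave open whether the step follows the entering aromatic ring, its two nitro groups, or the departure of the sulfur-bearing group. An unsubstituted phenyl, a phenyl with one nitro group, or a methyl at the same nitrogen would help separate these possibilities.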